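The source may hold more compounds than are shown below. What is called first, only, known or untested is meant among the compounds shown, and "the series" means these compounds.

Working notes on the series, read in an ADME assay on HEK293 cells (Homo sapiens) for cytotoxicity, read by reporter gene assay and resazurin assay, with a stated time of 48 h; on this read-out lower numbers stand for higher toxicity in this test and higher numbers for lower toxicity in this test. Going by the values given here, compound 1 (`O=C(Nc1cccc(Cl)c1)c1cc(Br)cc(Br)c1`) gives 53000 nM, the only true number so far. Compound 2 (`O=C(Nc1ccc(Sc2nc3ccccc3s2)c(Cl)c1)c1cccc(Br)c1`) reads > 100000 nM, which is a limit of the assay and not a number. Compound 3 (`COc1c(Br)cc(Br)cc1C(=O)Nc1ccc(Sc2nc3ccccc3s2)cc1`) reads > 100000 nM, which is also a limit. Compound 2 therefore stands at the limit of > 100000 nM in this assay, at which 2 of the 3 values shown sit.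

Next in line is compound 4 (`O=C(Nc1ccc(Sc2nc3ccccc3s2)c(Cl)c1)c1cc(Br)ccc1O`), which differs from compound 2 as follows: hydroxy in place of hydrogen on an aromatic carbon. Among the compounds with values here, no measured pair isolates this change, and compound 2 offers no number to start from, so any step is only loosely defined. Compound 1 at 53000 nM shows that a reading inside the range of this assay does occur in this series. A moderate move toward lower numbers is expected, though another limit remains possible. The expected size of the change is an at least 3.3-fold lower number from compound 2 to compound 4 (0.52 log units; beyond the scatter), and this is an estimate taken against a limit. For compound 4 the estimated value is 30000 nM, with an expected range of 6000 nM to 100000 nM.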

Compound 4, half-maximal cytotoxic concentration: 45000 nM
For compound 4 the middle estimate is 1.5-fold (0.18 log units) below the measured one; measured number inside the range.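

In this assay, going by these compounds alone, hydroxy in place of hydrogen, on the aromatic carbon ortho to a large group and para to a bromo group, gives an at least 2.2-fold lower number from compound 2 to compound 4 (0.34 log units; beyond the scatter), the first step that isolates a single change. Compound 4 gives 45000 nM, a true number, so this one change on the 3-bromophenyl group is enough to bring the reading inside the range of the assay. The reading of compound 2 is a limit and not a number, so the full size of the step stays unknown: the limit of > 100000 nM in this assay, at which 2 of the 4 values shown sit.

The compounds shown leave open whether an amine or a carboxylic acid on this same carbon would lower the number as hydroxy does. They also leave open whether hydroxy on another carbon of this ring would give a similar step.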